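Chloro for methoxy: expected cytotoxicity of compound 4

The compounds below may be only part of what the source reports. "The series", "measured", "known", "first", "only" and "open" are said of these compounds alone.

Three compounds share one core and have been tested in an ADME assay on L02 cells (Homo sapiens) for cytotoxicity, read by MTT assay; on this read-out lower numbers stand for stronger inhibition and higher numbers for weaker inhibition:

Compound 1 `COc1cc(/C=C/c2nc(Nc3ccc(O)cc3)c3sccc3n2)cc(OC)c1OC` gives 2300000 nM.
Compound 2 `COc1cc(/C=C/c2nc(NCc3ccccc3)c3sccc3n2)cc(OC)c1OC` gives 1800000 nM.
Compound 3 `COc1ccc(CNc2nc(/C=C/c3cc(OC)c(OC)c(OC)c3)nc3ccsc23)cc1` gives 2050000 nM.

Compound 3 sits second highest of the three numbers, but its gaps to the others are small: a 1.1-fold lower number from compound 1 to compound 3 (0.05 log units; within the scatter) and a 1.1-fold higher number from compound 2 to compound 3 (0.06 log units; within the scatter). All three numbers therefore read as one level.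

Compound 4 `COc1cc(/C=C/c2nc(NCc3ccc(Cl)cc3)c3sccc3n2)cc(OC)c1OC` is the next member. Compared with compound 3 the change is chloro in place of methoxy on an aromatic carbon.

Going by the values given here, two measured steps bear on this. The closest is a 1.1-fold higher number from compound 2 to compound 3 (0.06 log units; within the scatter), which touched the same aromatic carbon and moved nothing beyond the scatter. The exchanges of the whole group on the nitrogen, a 1.3-fold lower number from compound 1 to compound 2 (0.11 log units; within the scatter) and a 1.1-fold lower number from compound 1 to compound 3 (0.05 log units; within the scatter), were likewise flat. Every change tried so far at this end of the molecule has left this assay unmoved, so the expected step of a 1.0-fold lower number from compound 3 to compound 4 (0.01 log units; within the scatter) is none beyond the scatter.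

Compound 4 is estimated at 2000000 nM in this assay, with a range from 1000000 nM to 4000000 nM.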

Compound 4, half-maximal inhibitory concentration: 4320000 nM
Compound 4: the middle estimate sits 2.2-fold (0.33 log units) below what was measured, outside the stated range (above it).
By their numbers in this assay, from the lowest: compounds 2, 3, 1 and 4 (each within the scatter of the next, the first and the last beyond it).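

In this assay, this aromatic carbon of the benzyl group no longer looks indifferent: chloro in place of hydrogen gives a 2.4-fold higher number from compound 2 to compound 4 (0.38 log units; beyond the scatter), and chloro in place of methoxy gives a 2.1-fold higher number from compound 3 to compound 4 (0.32 log units; beyond the scatter), both modest shifts towards weaker inhibition. Hydrogen and methoxy at this carbon had read as one level, so among these three groups only chloro stands apart, and the earlier flat steps did not carry over to every group placed here. The wider exchange on the nitrogen, 4-chlorobenzyl in place of 4-hydroxyphenyl, gives a 1.9-fold higher number from compound 1 to compound 4 (0.27 log units; within the scatter), so compound 4 cannot be told apart from compound 1, and the shift is visible only against the two benzyl neighbours.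

Nothing available explains what sets chloro apart from hydrogen and methoxy at this carbon. Going by these compounds, whether fluoro, bromo, methyl or an amine on the same carbon would fall with chloro, or with hydrogen and methoxy, stays open.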